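From 2-methylphenyl to 3-hydroxyphenyl on the shared core

The source may report more compounds than this note shows. Statements on the series, on what has been measured and on what is new or still open speak of the compounds shown alone.

Measured so far in an ADME assay on BJ cells (Homo sapiens) for cytotoxicity, with a stated time of 72 h; on this read-out higher numbers stand for an effect only at larger amounts of compound and lower numbers for an effect already at smaller amounts:
Compound 1 `COc1cccc(-c2nc3c(c(C)nn3-c3ccccc3)c(-c3ccccc3O)c2C#N)c1` gives > 23000 nM as a limit
Compound 2 `CCc1ccc(-c2nc3c(c(C)nn3-c3ccccc3)c(-c3ccccc3Cl)c2C#N)cc1` gives > 20000 nM as a limit
Compound 3 `CCc1ccc(-c2nc3c(c(C)nn3-c3ccccc3)c(-c3ccccc3C)c2C#N)cc1` gives > 20000 nM as a limit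

All three entries are limits and not numbers. Compound 3 therefore has no number of its own in this assay and shares the limit of > 20000 nM in this assay, at which 2 of the 3 values shown sit, with compound 2, while the limit of > 23000 nM in this assay, at which 1 of the 3 values shown sits, belongs to compound 1.

Compound 4 `CCc1ccc(-c2nc3c(c(C)nn3-c3ccccc3)c(-c3cccc(O)c3)c2C#N)cc1` differs from compound 3 in one place: 3-hydroxyphenyl in place of 2-methylphenyl on an aromatic carbon. In words, 3-hydroxyphenyl stands in place of 2-methylphenyl on an aromatic carbon, ortho to a cyano group and opposite the ring nitrogen.

Going by the values given here, the only measured step, a step that the two limits leave unreadable from compound 2 to compound 3, has methyl in place of chloro on that same aryl ring and offers no size to carry over. Compound 1 also carries a hydroxyl on the phenyl ring at this place on the core, and its > 23000 nM is a limit as well.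

On this evidence, no step beyond the scatter and no particular direction is expected, and the expected step is a number no higher from compound 3 to compound 4 (the limit leaves the size open) for now. A further limit is the likeliest report. For compound 4 the estimate is 20000 nM, with an expected range from 8000 nM to 45000 nM for the measurement.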

Compound 4, half-maximal effective concentration: > 20000 nM
Compound 4 was reported as a limit; the forecaster's own chance of this, stated with the estimate: 75%; the middle value lies on the limit itself.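

In this assay compound 4 gives > 20000 nM, which is a limit and not a number. Going by these compounds alone, compound 2 and compound 3 also carry limits, so no step from either of them to compound 4 can be read. The compounds shown leave open whether any group at this place on the shared core would give an actual number in this assay.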